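Swapping an ortho difluoromethoxy for carbamoyl

The compounds below may be only part of what the source reports. "The series", "measured", "known", "first", "only" and "open" are said of these compounds alone.

Measured compounds:
compound 1 `FC(F)Oc1ccccc1C1Cc2nccn2C1` gives 75%
compound 2 `c1ccc(C2CCc3nccn3C2)cc1` gives 68%
compound 3 `COc1cccc(C2CCc3nc[nH]c3C2)c1` gives 60%

In a functional assay on CHO cells for agonist activity at Alpha-1A adrenergic receptor (Homo sapiens), read by FLIPR and calcium flux (on this read-out lower numbers stand for smaller maximal responses and higher numbers for larger maximal responses), compound 1 gives the top number of the three. Compound 2 comes closest, and its gap to compound 1 lies within the usual scatter, so the two cannot be told apart. Compound 3 lies furthest away, and that gap is beyond the scatter, so compound 3 does reach a smaller maximal response than compound 1.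

Compound 4 `NC(=O)c1ccccc1C1Cc2nccn2C1` has not yet been measured. It differs from compound 1 in one place: carbamoyl in place of difluoromethoxy on an aromatic carbon. The difluoromethoxy group leaves, and a carbamoyl group, which brings a hydrogen-bond donor, enters on the same aromatic carbon.

Going by the values given here, no pair among the measured compounds shows a comparable change, so the expectation rests on the spread seen so far, which is modest. A step downward of moderate size in this assay is expected, a number 15 percentage points lower from compound 1 to compound 4 (beyond the scatter), with a real chance of no change beyond the scatter. Compound 4 is therefore estimated at 60%, with a plausible range from 35% to 85%.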

Compound 4, largest response reached (Emax), in percent of the reference or control that the assay uses: 87%
Beside the measured number, compound 4's estimate is 27 percentage points below it; measured number outside the range, above it.
By their numbers in this assay, from the lowest: compounds 3, 2 and 1 (each within the scatter of the next, the first and the last beyond it); then compound 4.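

Replacing difluoromethoxy with carbamoyl on this aromatic carbon gives a number 12 percentage points higher from compound 1 to compound 4 (beyond the scatter) in this assay. Going by these compounds alone, this pair is the first in the set to differ in one place only, so it offers the first direct look at how the maximal response changes with the group at this position. The position does respond to a change of group, and here the carbamoyl group, which brings a hydrogen-bond donor, raises the maximal response rather than lowering it.

As far as these compounds go, whether an amine, a carboxylic acid or a nitrile on the same aromatic carbon would also raise the response remains open, and so does whether the amide hydrogen plays any part in this rise. No separate measurement accompanies this pair, so what lies behind the rise remains unknown.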